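Compound 3 loses its amino group

The source may hold more compounds than are shown below. What is called first, only, known or untested is meant among the compounds shown, and "the series" means these compounds.

Going by the values given here, in a functional assay on the whole organism for antagonist activity, with Mus musculus as the target (a lower number here means that less compound is needed, a higher number that more compound is needed for the effect), compound 3 (`CCN(CC)CC(=O)NCC(=O)N(C)c1ccc(Cl)cc1C(=O)c1ccccc1Cl`) gives the lowest of the three numbers so far (2.2 mg/kg). Compound 1 (`CN(C(=O)CNC(=O)CN1CCCCC1)c1ccc(Cl)cc1C(=O)c1ccccc1Cl`) stands higher (7.5 mg/kg), and compound 2 (`CN1CCN(CC(=O)NCC(=O)N(C)c2ccc(Cl)cc2C(=O)c2ccccc2Cl)CC1`) higher still (59 mg/kg).

Compound 4 (`CCCCC(=O)NCC(=O)N(C)c1ccc(Cl)cc1C(=O)c1ccccc1Cl`) differs from compound 3 at one place, with propyl in place of diethylamino on a saturated chain carbon bound to a carbonyl carbon. The shared core stays the same.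

The closest evidence comes from changes at this same place, each trading one amino group for another. They produced two modest steps (a 3.4-fold lower number from compound 1 to compound 3 (0.53 log units; beyond the scatter); a 7.9-fold higher number from compound 1 to compound 2 (0.90 log units; beyond the scatter)) and a large one (a 27-fold lower number from compound 2 to compound 3 (1.43 log units; beyond the scatter)). None of them removes the amino group, so they offer only a rough guide to size. Compound 3 already holds the lowest number (2.2 mg/kg), and both other amino groups gave higher ones, so a modest to large rise is expected (a 5.5-fold higher number from compound 3 to compound 4 (0.74 log units; beyond the scatter)). For compound 4 the estimated value is 12 mg/kg with an expected range from 2.5 mg/kg to 60 mg/kg at its outer ends.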

Compound 4, dose for half-maximal effect: 1.3 mg/kg
Compound 4: middle estimate off by 9.2-fold (0.97 log units), on the high side, outside the stated range (below it).
By their numbers in this assay, from the lowest: compounds 4 and 3 (each within the scatter of the next); then compound 1; then compound 2.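

In this assay, the amino group on this saturated chain carbon bound to a carbonyl carbon proves dispensable: with propyl, which holds no nitrogen, in place of diethylamino, the two numbers lie within the scatter of each other (a 1.7-fold lower number from compound 3 to compound 4 (0.23 log units; within the scatter)). Going by these compounds alone, the earlier steps traded only one amino group for another, whereas propyl also gives clear steps against the two ring groups, both from piperidin-1-yl (a 5.8-fold lower number from compound 1 to compound 4 (0.76 log units; beyond the scatter)) and from 4-methylpiperazin-1-yl (a 45-fold lower number from compound 2 to compound 4 (1.66 log units; beyond the scatter)). Nothing measured here explains these differences.

As far as these compounds go, it remains open whether a longer chain such as hexyl would keep the number this low. A carboxylic acid or a primary amine at this place could also give a different result.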